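Phenyl on the ring nitrogen: a step without precedent

The source may hold more compounds than are shown below. What is called first, only, known or untested is meant among the compounds shown, and "the series" means these compounds.

Compound 1 `O=C1NN=C(c2ccccc2)/C1=C/Nc1cc(-c2ccco2)[nH]n1` belongs to a small set of three analogues that share one core and differ at a single aromatic carbon. In a functional assay on MDA-MB-453 cells (Homo sapiens) for antiproliferative activity, read by MTT assay, with a stated time of 72 h (a higher number here means a weaker inhibitor, a lower number a stronger inhibitor), compound 1 gives 20900 nM, the second highest of the three numbers. Compound 3 `O=C1NN=C(c2ccccc2)/C1=C/Nc1cc(-c2ccccc2)[nH]n1` is nearest, giving 11500 nM; the gap a 1.8-fold lower number from compound 1 to compound 3 (0.26 log units; within the scatter) lies within the scatter. Compound 2 `Cc1cc(N/C=C2\C(=O)NN=C2c2ccccc2)n[nH]1` is furthest, giving 93000 nM; the gap a 4.4-fold higher number from compound 1 to compound 2 (0.65 log units; beyond the scatter) lies beyond it, as does the step of an 8.1-fold lower number from compound 2 to compound 3 (0.91 log units; beyond the scatter).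

Compound 4 `O=C1/C(=C\Nc2cc(-c3ccco3)[nH]n2)C(c2ccccc2)=NN1c1ccccc1` differs from compound 1 elsewhere: phenyl in place of hydrogen on an amide-type nitrogen in a ring. None of the three measured steps touches this nitrogen; each of them exchanges the group on the aromatic carbon of the other ring, leaving the amide-type nitrogen with its hydrogen throughout. For the measured compounds named here, there is therefore no measured step that bears on the change from compound 1 to compound 4, and the size of its effect in this assay is simply unknown from these data.

With nothing to lean on, the most defensible expectation is no step beyond the scatter from compound 1 to compound 4, the expected step being a 1.0-fold lower number from compound 1 to compound 4 (0.02 log units; within the scatter). Compound 4 is thus estimated at 20000 nM in this assay, within a broad range from 4000 nM to 100000 nM.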

Compound 4, half-maximal inhibitory concentration: 12400 nM
Estimate against measurement, compound 4: 1.6-fold (0.21 log units) above; low and high end bracket the measured number.
By their numbers in this assay, from the lowest: compounds 3, 4 and 1 (each within the scatter of the next); then compound 2.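

For the compounds shown here, replacing the hydrogen on the amide-type nitrogen with a phenyl gives the first reading at this position, where the earlier compounds all keep their hydrogen: in this assay the step is a 1.7-fold lower number from compound 1 to compound 4 (0.23 log units; within the scatter) and so cannot be told apart from no effect. For this pair, then, the amide hydrogen is not required for the antiproliferative activity seen with compound 1, and a group as large as phenyl, with its 6 heavy atoms, can stand on this nitrogen without a loss beyond the scatter. The compounds offer no measurement that would explain this result.

From the compounds shown here alone, whether other groups would behave the same way on this nitrogen remains open, for example an ethyl, a longer alkyl chain, a benzyl or a phenyl carrying a carboxylic acid or an amine. It is also unknown whether the phenyl on this nitrogen would give a similar step with the phenyl of compound 3 or the methyl of compound 2 on the aromatic carbon, in place of the furan-2-yl group shared by compound 1 and compound 4.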